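What compound 4 may give after the ring exchange

This account rests on a few compounds, and the source may have more. Where it says the series, first, only, none or still open, it means among the compounds named here.

Three compounds share a core in which a saturated chain carbon bound to a sulfur carries a varied aromatic group. Compound 1 `Cc1scc(C[S+]([O-])C(c2ccccc2)c2ccccc2)c1C` gives 284000 nM in an assay on HEK293 cells for inhibition of sodium-dependent dopamine transporter (Homo sapiens), read by scintillation counting, with stated times of 5 min and 1 min; a higher number here means a weaker inhibitor, a lower number a stronger inhibitor. Compound 2 `Cc1cc(O)nc(C[S+]([O-])C(c2ccccc2)c2ccccc2)n1` gives 109000 nM in this assay, and compound 3 `[O-][S+](Cc1nc(O)cc(C(F)(F)F)n1)C(c1ccccc1)c1ccccc1` gives 40400 nM. Compound 2 thus holds the second highest of the three numbers: a 2.6-fold lower number from compound 1 to compound 2 (0.42 log units; beyond the scatter) separates it from compound 1, and a 2.7-fold lower number from compound 2 to compound 3 (0.43 log units; beyond the scatter) separates it from compound 3.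

Compound 4 `[O-][S+](Cc1csc(Br)c1)C(c1ccccc1)c1ccccc1` differs from compound 2 in one place: 5-bromothiophen-3-yl in place of 4-hydroxy-6-methylpyrimidin-2-yl on a saturated chain carbon bound to a sulfur. Going by the values given here, of the two measured steps, the one from compound 1 to compound 2 bears on this change most directly, as it also set a thiophene against the 4-hydroxy-6-methylpyrimidin-2-yl group, and it gave a 2.6-fold lower number from compound 1 to compound 2 (0.42 log units; beyond the scatter). The step from compound 2 to compound 3 alters a group on the ring that now leaves and offers no guidance here. Compound 4 returns to a thiophene, so a step back toward the number of compound 1 is expected, beyond the scatter and toward a weaker inhibitor. Compound 4 is therefore estimated to give about 220000 nM in this assay, within a range from 90000 nM to 500000 nM. This estimate amounts to an expected 2.0-fold higher number from compound 2 to compound 4 (0.30 log units; within the scatter).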

Compound 4, half-maximal inhibitory concentration: 16600 nM
For compound 4 the middle estimate is 13-fold (1.12 log units) above the measured one; measured number outside the range, below it.
By their numbers in this assay, from the lowest: compound 4; then compound 3; then compound 2; then compound 1.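

In this assay, the exchange on a saturated chain carbon bound to a sulfur gives a 6.6-fold lower number from compound 2 to compound 4 (0.82 log units; beyond the scatter), so a thiophene at this place need not give a higher number than the 4-hydroxy-6-methylpyrimidin-2-yl group. The two thiophene-bearing compounds also lie far apart, with a 17-fold lower number from compound 1 to compound 4 (1.23 log units; beyond the scatter), which shows that the earlier step from a thiophene to the pyrimidine reflected that one substituted thiophene and not thiophenes as a class; the substituents on the ring can matter at least as much as the ring itself. Nothing available explains either step, and the loss of the hydroxy group cannot be separated from the arrival of the bromine in the exchange from compound 2.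

From the compounds shown here alone, the step from compound 1 to compound 4 changes the two methyl groups, the bromine and their places on the ring together, so the share of each remains unknown. A thiophene with chlorine in place of the bromine, one carrying no substituent, or a 3-bromophenyl group at the same place would help to show whether the bromine or the thiophene carries the lower number.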